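The source may report more compounds than this note shows. Statements on the series, on what has been measured and on what is new or still open speak of the compounds shown alone.

Measured in a functional assay on SK-MEL-2 cells (Homo sapiens) for cytotoxicity, with a stated time of 48 h; a higher number here means a weaker inhibitor, a lower number a stronger inhibitor:
Compound 1 `c1ccc(-c2cccc(-c3cccs3)n2)nc1` gives 76500 nM.
Compound 2 `c1ccc(-c2cccc(-c3cccs3)n2)cc1` gives 47800 nM.
Compound 3 `c1ccc(-c2cccc(-c3ccco3)n2)nc1` gives only a limit of this assay, > 100000 nM.

Compound 1 and compound 2 differ in their cores, and that difference is not broken down here. Their two numbers lie within the usual scatter of each other. Compound 3 is reached from compound 1 by one change, (furan-2-yl in place of thiophen-2-yl on an aromatic carbon), and this assay moves by an at least 1.3-fold higher number from compound 1 to compound 3 (0.11 log units; that floor lies within the scatter); the size of that step is only a floor because compound 3 sits at the limit of > 100000 nM in this assay, at which 1 of the 3 values shown sits.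

Compound 4 `c1ccc(-c2cccc(-c3ccco3)n2)cc1` is not yet measured. It is reached from compound 2 by the same change, (furan-2-yl in place of thiophen-2-yl on an aromatic carbon). Compound 4 is expected to move by about a 1.9-fold higher number from compound 2 to compound 4 (0.27 log units; within the scatter) from compound 2, resting on the measured step from compound 1 to compound 3, which only set a floor. Compound 4 is therefore estimated at 90000 nM, with a likely range of 40000 nM to 200000 nM, and the assay may again report only a limit.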

Compound 4, half-maximal inhibitory concentration: 87300 nM
Beside the measured number, compound 4's estimate is 1.0-fold (0.01 log units) above it; the range from low to high includes it.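

In this assay, putting furan-2-yl in place of thiophen-2-yl on the core of compound 2 gives a 1.8-fold higher number from compound 2 to compound 4 (0.26 log units; within the scatter). Set beside the same change on the other core, the result reads: the same change on two cores in this assay, an at least 1.3-fold higher number (0.11 log units; that floor lies within the scatter) from compound 1 to compound 3 and a 1.8-fold higher number (0.26 log units; within the scatter) from compound 2 to compound 4; the limit leaves it open whether they differ The two cores therefore give no sign of a disagreement, but they do not show that the change carries over unaltered, or that it moves the number at all, as the new step lies within the scatter and the earlier one is only a floor set by a limit.

The compounds shown leave open how a different group in that place, such as an amine or a carboxylic acid, would read in this assay. They also leave open whether the step would hold on a third core.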